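The source may report more compounds than this note shows. Statements on the series, on what has been measured and on what is new or still open speak of the compounds shown alone.

Going by the values given here, compound 1 `O=C(CBr)Nc1ccc(C(=O)/C=C/c2ccc(Cl)cc2)cc1` gives 59% in a functional assay on the whole organism (strain albino) for inhibition, with Rattus norvegicus as the target, read by paw edema, with stated times of 30 min and 3 h, at a dose of 100 mg/kg by the oral route (on this read-out lower numbers stand for less inhibition and higher numbers for more inhibition at the one dose given (going by the name of the read-out)), and compound 2 `O=C(CBr)Nc1ccc(C(=O)/C=C/c2ccco2)cc1` gives 41%, the lowest of the two numbers; the change a number 18 percentage points lower from compound 1 to compound 2 (beyond the scatter) is the only step measured. Compound 3 `O=C(CO[N+](=O)[O-])Nc1ccc(C(=O)/C=C/c2ccco2)cc1` differs from compound 2 by nitrooxy in place of bromo on a saturated chain carbon bound to a carbonyl carbon. Among the compounds with values here, no measured step touches the saturated chain carbon bound to the carbonyl carbon, so nothing in the data shows which way this change moves the inhibition. Compound 3 is therefore expected to lie near compound 2, with no change at the digits printed from compound 2 to compound 3 (within the scatter) estimated as no step beyond the scatter, giving an estimate of 41% within 22% to 60%.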

Compound 3, a percentage reported as inhibition, in the whole organism at one dose (the size of the read-out at that dose, not a potency): 48%
Compound 3: the middle estimate sits 7 percentage points below what was measured; measured number inside the range.
By their numbers in this assay, from the lowest: compounds 2 and 3 (each within the scatter of the next); then compound 1.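

Nitrooxy in place of bromo on a saturated chain carbon bound to a carbonyl carbon gives, in this assay, a number 7 percentage points higher from compound 2 to compound 3 (within the scatter), the first step read at this position. With furan-2-yl in the molecule, then, bromo can give way to nitrooxy, with its larger count of heavy atoms and hydrogen-bond acceptors, without a change beyond the scatter at this one dose. Nothing at hand explains this result.

From the compounds shown here alone, what an amine or a carboxylic acid on this carbon would give remains open. So does whether the same change would read alike with 4-chlorophenyl in place of furan-2-yl.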